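Propyl to Isopropyl on the Pyrazole Nitrogen

The source may report more compounds than this note shows. Statements on the series, on what has been measured and on what is new or still open speak of the compounds shown alone.

Measured compounds:
compound 1, `O=C(NCc1ccc(S(=O)(=O)c2cncc(C(F)(F)F)c2)cc1)N1Cc2ccncc2C1`, 15 nM in an assay on isolated protein for inhibition of Nicotinamide phosphoribosyltransferase (Homo sapiens), read by mass spectrometry, with stated times of 15 min and 30 min; a higher number here means a weaker inhibitor, a lower number a stronger inhibitor
compound 2, `O=C(NCc1ccc(S(=O)(=O)c2cc(F)cc(F)c2)cc1)N1Cc2ccncc2C1`, 7.1 nM
compound 3, `CCCn1cc(S(=O)(=O)c2ccc(CNC(=O)N3Cc4ccncc4C3)cc2)cn1`, 17 nM

Among these three numbers compound 3 stands highest. Its nearest neighbour is compound 1, with the step of a 1.1-fold higher number from compound 1 to compound 3 (0.05 log units; within the scatter) lying within the scatter, so no order can be read between the two. Compound 2 is furthest away, the step of a 2.4-fold higher number from compound 2 to compound 3 (0.38 log units; beyond the scatter) being a modest one beyond the scatter.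

Compound 4, `CC(C)n1cc(S(=O)(=O)c2ccc(CNC(=O)N3Cc4ccncc4C3)cc2)cn1`, differs from compound 3 by isopropyl in place of propyl on an aromatic nitrogen; the two share every atom and are joined differently.

Within the data shown here, none of the measured steps touches this change. The steps of a 2.1-fold lower number from compound 1 to compound 2 (0.32 log units; beyond the scatter), a 1.1-fold higher number from compound 1 to compound 3 (0.05 log units; within the scatter) and a 2.4-fold higher number from compound 2 to compound 3 (0.38 log units; beyond the scatter) each exchange the whole group on the sulfonyl sulfur, and even those whole-group swaps stay modest or within the scatter. A rearrangement of the chain on the aromatic nitrogen therefore gives no ground to expect any step beyond the scatter in this assay, in either direction. The expected step is accordingly no change at the digits printed from compound 3 to compound 4 (within the scatter). Compound 4 is estimated at 17 nM, with a range from 8 nM to 36 nM.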

Compound 4, half-maximal inhibitory concentration: 20 nM
Estimate against measurement, compound 4: 1.2-fold (0.07 log units) below; measured number inside the range.
By their numbers in this assay, from the lowest: compound 2; then compounds 1, 3 and 4 (each within the scatter of the next).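

In this assay, isopropyl in place of propyl on the aromatic nitrogen gives a 1.2-fold higher number from compound 3 to compound 4 (0.07 log units; within the scatter) and so shows that this rearrangement of the chain, with the atoms unchanged, leaves the number inside the scatter. The 1-isopropyl-1H-pyrazol-4-yl group also stands as the propyl group did against the other two groups on the sulfonyl sulfur, with a 1.3-fold higher number from compound 1 to compound 4 (0.12 log units; within the scatter) still inside the scatter and a 2.8-fold higher number from compound 2 to compound 4 (0.45 log units; beyond the scatter) as a modest step beyond it. No measurement is available that explains either result.

On these data alone, it remains open whether a longer chain such as butyl, a cyclopropyl ring or a chain ending in an amine on this nitrogen would also stay within the scatter. The pyrazole with only a hydrogen on this nitrogen is likewise left open.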